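Cyclopropylamino to 4-Fluorobenzylamino on the Shared Core

The compounds below may be only part of what the source reports. "The series", "measured", "known", "first", "only" and "open" are said of these compounds alone.

In a functional assay on CHO cells for antagonist activity at adenosine receptor A2b (Homo sapiens) (a higher number here means a weaker inhibitor, a lower number a stronger inhibitor), compound 3 `CCOC(=O)c1cnc(NC2CC2)n2nc(-c3ccco3)nc12` gives 2260 nM. Within the data shown here, this is the only numerical value in the set; the other two entries are limits. Compound 1 `COc1ccc(CNc2ncc(C(=O)O)c3nc(-c4ccco4)nn23)cc1OC` reaches only the assay limit of > 30000 nM. Compound 2 `O=C(Nc1ncc(C(=O)O)c2nc(-c3ccco3)nn12)NC1CCCCC1` likewise stops at the limit of > 30000 nM. Among the measured compounds shown here, compound 3 therefore stands alone as the one compound with a measured number, while the other two sit at the limit of > 30000 nM in this assay, at which 2 of the 3 values shown sit. For the measured compounds named here, no pair of measured compounds differs in a single place, so no measured step size is available to calibrate the change below.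

Compound 4 `CCOC(=O)c1cnc(NCc2ccc(F)cc2)n2nc(-c3ccco3)nc12` has not been measured. It differs from compound 3 by 4-fluorobenzyl in place of cyclopropyl on a nitrogen on an aromatic ring. Neither compound 1 nor compound 2 shares the ethyl ester of compounds 3 and 4, so their limits say nothing about the amine exchange. Going by the values given here, with no comparable step in hand, the step from compound 3 to compound 4 is expected to be modest, a 1.9-fold lower number from compound 3 to compound 4 (0.27 log units; within the scatter), towards a somewhat stronger inhibitor but not clearly beyond the scatter. For compound 4 a value of 1200 nM is estimated, within 300 nM to 6000 nM.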

Compound 4, inhibition constant: 1970 nM
For compound 4 the middle estimate is 1.6-fold (0.22 log units) below the measured one; low and high end bracket the measured number.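

In this assay, the exchange of cyclopropyl for 4-fluorobenzyl on a nitrogen on an aromatic ring gives a 1.1-fold lower number from compound 3 to compound 4 (0.06 log units; within the scatter). Compounds 3 and 4 are the only pair shown that differs in one place, and this pair shows that, with the ethyl ester kept, an amine substituent of 8 heavy atoms with a six-membered aromatic ring reads the same in this assay as one of 3 heavy atoms with a three-membered ring. Nothing shown bears on why the two values coincide.

Steps from compounds 3 and 4 to compounds 1 and 2 cannot be read, as those pairs differ in more than one place. Still open, from the compounds shown here alone, is how this assay responds to a plain benzyl or a longer chain such as 2-phenylethyl on that nitrogen, or to a primary amide in place of the ethyl ester.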